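A few compounds are considered here, and "the series" means these few. Any claim that something is new, unique, unknown or untested is made for them only; others in the source may bear on it.

Compound 1 `O=S(=O)(Nc1ccncc1Nc1cccc(Br)c1)C(F)(F)F`: 27.1%
Compound 2 `O=S(=O)(Nc1ccncc1Nc1ccc(F)c(Cl)c1)C(F)(F)F`: 14.7%

In a functional assay on the whole organism (strain Wistar) with Rattus norvegicus as the target, with stated times of 30 min and 4 h, at a dose of 5 mg/kg by the intraperitoneal route (a higher number here means a stronger effect of the compound at the dose given, a lower number a weaker effect), compound 1 gives 27.1%, while compound 2 gives 14.7%, the lower of the two numbers and a gap beyond the scatter. Compound 3 `O=S(=O)(Nc1ccncc1Nc1ccc(F)c(Br)c1)C(F)(F)F` has not yet been measured in this assay. It differs from compound 2 in one place: bromo in place of chloro on an aromatic carbon. Some gain is expected for compound 3 because compound 1 gives 27.1% with a bromo group present, though without the fluoro group. The expected step of a number 7.3 percentage points higher from compound 2 to compound 3 (within the scatter) is modest, only at the edge of the scatter. Compound 3 is therefore estimated at 22%, with a range from 8% to 36%.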

Compound 3, a percentage reported as activity, at one dose (the size of the read-out at that dose, not a potency): 11.1%
For compound 3 the middle estimate is 10.9 percentage points above the measured one, and the stated range covers the measured number.
By their numbers in this assay, from the lowest: compounds 3 and 2 (each within the scatter of the next); then compound 1.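

In this assay, bromo in place of chloro on this aromatic carbon, ortho to a fluoro group, gives a number 3.6 percentage points lower from compound 2 to compound 3 (within the scatter) and so does not separate these two halogens at this place. For the compounds shown here, with bromo kept, fluoro in place of hydrogen on an aromatic carbon gives a number 16 percentage points lower from compound 1 to compound 3 (beyond the scatter) and is the only step here that clears the scatter. Nothing available here accounts for either step. Going by these compounds, whether a nitrile, a methoxy group or an amine at the place of the bromo would stand apart from the two halogens remains open.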